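Notes on the dinitrophenyl series: acyl variation

The compounds below may be only part of what the source reports. "The series", "measured", "known", "first", "only" and "open" are said of these compounds alone.

Measured in a toxicity assay on KB cells (Homo sapiens) for cytotoxicity, read by fluorescence, with a stated time of 3 days; on this read-out lower numbers stand for an effect already at smaller amounts and higher numbers for an effect only at larger amounts of compound:
compound 1 `CCCCOC(=O)CNC(=O)[C@H](CSc1ccc([N+](=O)[O-])cc1[N+](=O)[O-])NC(=O)CC[C@H](NC(=O)CC(C)C)C(=O)OCCCC`: 59.6 uM.
compound 2 `CCCCOC(=O)CNC(=O)[C@H](CSc1ccc([N+](=O)[O-])cc1[N+](=O)[O-])NC(=O)CC[C@H](NC(=O)CCc1ccccc1)C(=O)OCCCC`: a limit, > 300 uM.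
compound 3 `CCCCOC(=O)CNC(=O)[C@H](CSc1ccc([N+](=O)[O-])cc1[N+](=O)[O-])NC(=O)CC[C@H](Nc1nc(N)nc(Cl)n1)C(=O)OCCCC`: a limit, > 300 uM.

Compound 2 stands at the limit of this assay, where two of the three values sit (the limit of > 300 uM in this assay, at which 2 of the 3 values shown sit). Compound 4 `CCCCOC(=O)CNC(=O)[C@H](CSc1ccc([N+](=O)[O-])cc1[N+](=O)[O-])NC(=O)CC[C@H](NC(=O)c1ccccc1)C(=O)OCCCC` differs from compound 2 by phenyl in place of phenethyl on a carbonyl carbon, phenethylcarbonyl to benzoyl. For the measured compounds named here, no measured step exchanges phenethyl for phenyl. The steps that do bear on the acyl position, an at least 5.0-fold higher number from compound 1 to compound 2 (0.70 log units; beyond the scatter) and an at least 5.0-fold higher number from compound 1 to compound 3 (0.70 log units; beyond the scatter), both lead away from compound 1 to a limit; a step that the two limits leave unreadable from compound 2 to compound 3 is not readable. With compound 2 itself at a limit, a step of an at least 1.5-fold lower number from compound 2 to compound 4 (0.17 log units; that floor lies within the scatter) is expected to remain unreadable or small. Compound 4 is estimated at 200 uM, range 50 uM to 600 uM.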

Compound 4, concentration for half-maximal effect: > 300 uM
Compound 4 ended at the assay's limit; the forecaster's own chance of this, stated with the estimate: 60%; middle value at least 1.5-fold (0.17 log units) away from the limit.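

Benzoyl on this amine nitrogen also leads away from compound 1, with an at least 5.0-fold higher number from compound 1 to compound 4 (0.70 log units; beyond the scatter). Moving the aromatic ring directly onto the carbonyl carbon therefore brings no readable value in this assay, where compound 4 also stands at a limit: the limit of > 300 uM in this assay, at which 3 of the 4 values shown sit. For the compounds shown here, the steps linking compound 2, compound 3 and compound 4 cannot be read, and compound 1 remains the only compound here with a measured number.

Going by these compounds, whether acetyl, a longer branched alkyl chain or a carboxylic acid on the acyl chain would give a number stays open. So does how far phenethyl, phenyl and the triazinyl group actually differ.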